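Replacing 1H-imidazol-1-yl with trifluoromethyl on the shared core

The compounds below may be only part of what the source reports. "The series", "measured", "known", "first", "only" and "open" are said of these compounds alone.

Values measured in a functional assay for inhibition, with Rattus norvegicus as the target (a lower number here means a stronger inhibitor, a higher number a weaker inhibitor), are these
compound 1 `CC(/N=c1\c(O)c(O)\c1=N/c1ccc(C#N)cc1)C(C)(C)C` gives 520 nM as a number
compound 2 `CC(/N=c1\c(O)c(O)\c1=N/c1ccc(S(C)(=O)=O)cc1)C(C)(C)C` gives > 30000 nM as a limit
compound 3 `CC(/N=c1\c(O)c(O)\c1=N/c1ccc(-n2ccnc2)cc1)C(C)(C)C` gives > 30000 nM as a limit

Compound 3 stands at its limit of > 30000 nM and has no number. Among the compounds with values here, compound 4 `CC(/N=c1\c(O)c(O)\c1=N/c1ccc(C(F)(F)F)cc1)C(C)(C)C` carries trifluoromethyl in place of 1H-imidazol-1-yl on an aromatic carbon and no step between these two groups has been measured. Within the data shown here, two measured steps bear on it, an at least 57-fold higher number from compound 1 to compound 3 (1.76 log units; beyond the scatter) with 1H-imidazol-1-yl in place of cyano and an at least 57-fold higher number from compound 1 to compound 2 (1.76 log units; beyond the scatter) with methylsulfonyl in place of cyano, both large and beyond the scatter. Compound 1 keeps a number of 520 nM with cyano there, and trifluoromethyl is neither methylsulfonyl nor 1H-imidazol-1-yl, so a large step toward a lower number is expected, though with wide doubt. The expected change is an at least 10-fold lower number from compound 3 to compound 4 (1.00 log units; beyond the scatter) in this assay on this reasoning. Compound 4 is estimated at 3000 nM with an expected range from 400 nM to 25000 nM on this estimate.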

Compound 4, half-maximal inhibitory concentration: > 30000 nM
Compound 4 ended at the assay's limit (the forecaster's own chance of this, stated with the estimate: 25%); at least 10-fold (1.00 log units) between middle value and limit.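

In this assay, trifluoromethyl in place of cyano gives an at least 57-fold higher number from compound 1 to compound 4 (1.76 log units; beyond the scatter), so a third replacement on this aromatic carbon, and one without a ring or hydrogen-bond acceptors, also ends at a limit. Of the four groups shown, only cyano, in compound 1, gives a number. The steps among compound 2, compound 3 and compound 4 cannot be read: the limit of > 30000 nM in this assay, at which 3 of the 4 values shown sit.

Going by these compounds, the true values behind these three limits remain open. So does whether an amine, a carboxylic acid or a single chlorine atom at this place would give a number.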